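A few compounds are considered here, and "the series" means these few. Any claim that something is new, unique, unknown or untested is made for them only; others in the source may bear on it.

Working notes on the series in a functional assay on L1210 cells (Mus musculus) for inhibition; a lower number here means a stronger inhibitor, a higher number a weaker inhibitor. Compound 1 `Cc1ccc(Cn2cc(C(=N)S)c3c(N)ncnc32)cc1` gives > 10000 nM in this assay; this is a limit of the assay and not a number. Compound 2 `NC(=S)c1cn(COCc2ccccc2)c2ncnc(N)c12` gives 100000 nM in this assay. Compound 3 `Cn1cc(C(=N)S)c2c(N)ncnc21` gives 38000 nM in this assay. The step that the limit leaves unreadable from compound 1 to compound 3 cannot be sized because the limit of > 10000 nM in this assay, at which 1 of the 3 values shown sits, hides where compound 1 truly sits.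

Compound 4 `Cc1ccc(Cn2cc(C(N)=O)c3c(N)ncnc32)cc1` differs from compound 1 in one place: a group of 3 heavy atoms (1 carbon, 1 nitrogen, 1 oxygen; no ring) in place of a group of 3 heavy atoms (1 carbon, 1 nitrogen, 1 sulfur; no ring), on an aromatic carbon. For the measured compounds named here, no measured step touches this position or this exchange; the only measured step, from compound 1 to compound 3, concerns a different place and is itself unreadable. All three measured values sit at weak inhibition, and nothing in the data points to a shift beyond the scatter for compound 4. The step that the limit leaves unreadable from compound 1 to compound 4 is therefore an expectation of no movement beyond the scatter. Compound 4 is estimated at 30000 nM, with a range from 10000 nM to 100000 nM, and a real chance that this assay again reports only a limit.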

Compound 4, half-maximal inhibitory concentration: 20000 nM
For compound 4 the middle estimate is 1.5-fold (0.18 log units) above the measured one, and the stated range covers the measured number.
By their numbers in this assay, from the lowest: compounds 4 and 3 (each within the scatter of the next); then compound 2.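

No new step can be read between compound 4 and compound 1 in this assay, because compound 1 carries only a limit of the assay and not a number: the limit of > 10000 nM in this assay, at which 1 of the 4 values shown sits.

The compounds shown leave open what exchanging that group for carbamoyl does to inhibition on the shared core.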